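A Methylsulfonyl Group on Compound 2

The source may report more compounds than this note shows. Statements on the series, on what has been measured and on what is new or still open speak of the compounds shown alone.

In a functional assay on HCC827 cells (Homo sapiens) for antiproliferative activity, read by MTT assay, with a stated time of 72 h (a lower number here means a stronger inhibitor, a higher number a weaker inhibitor), compound 2 `CN1CCN(c2ccc(Nc3ncc4nc(Nc5ccccc5)n([C@@H]5CCNC5)c4n3)cc2)CC1` gives 65 nM, and compound 1 `CN1CCN(c2ccc(Nc3ncc4nc(Nc5ccccc5)n([C@H]5CCN(C(=O)OC(C)(C)C)C5)c4n3)cc2)CC1` gives 110 nM. For the measured compounds named here, these are the only two measurements so far, and they lie within the scatter of each other, so compound 2 cannot be separated from compound 1. Compound 3 `CN1CCN(c2ccc(Nc3ncc4nc(Nc5ccccc5)n([C@H]5CCN(S(C)(=O)=O)C5)c4n3)cc2)CC1` carries 1-(methylsulfonyl)pyrrolidin-3-yl in place of pyrrolidin-3-yl on an aromatic nitrogen. Going by the values given here, one measured step bears on this place: a 1.7-fold lower number from compound 1 to compound 2 (0.23 log units; within the scatter), with pyrrolidin-3-yl replacing 1-(tert-butoxycarbonyl)pyrrolidin-3-yl. Among the compounds with values here, that step is small, but it is the only guide, and no compound with a methylsulfonyl group has yet been measured. No change beyond the scatter is therefore expected in this assay. The estimated step is a 1.4-fold higher number from compound 2 to compound 3 (0.14 log units; within the scatter). The expected value for compound 3 is 90 nM, with an estimated range from 30 nM to 270 nM.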

Compound 3, half-maximal inhibitory concentration: 17 nM
The estimate for compound 3 lay 5.3-fold (0.72 log units) above the measured number; measured number outside the range, below it.
By their numbers in this assay, from the lowest: compound 3; then compounds 2 and 1 (each within the scatter of the next).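

In this assay, for the compounds shown here, this position on the aromatic nitrogen responds to what is attached to the amine nitrogen in the ring: 1-(methylsulfonyl)pyrrolidin-3-yl in place of pyrrolidin-3-yl gives a 3.8-fold lower number from compound 2 to compound 3 (0.58 log units; beyond the scatter) and is the first change here to exceed the scatter. Methylsulfonyl in place of tert-butoxycarbonyl gives a 6.5-fold lower number from compound 1 to compound 3 (0.81 log units; beyond the scatter) and so sets compound 3 apart from both earlier compounds, which could not be separated from each other. No measurement shown accounts for this result.

The compounds shown leave open whether the lower number is specific to methylsulfonyl or would also appear with ethylsulfonyl, phenylsulfonyl or an acetyl group on the same nitrogen. They also leave open whether it would hold in cells other than those of this single assay.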